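The compounds below may be only part of what the source reports. "The series", "measured", "known", "first", "only" and "open" are said of these compounds alone.

Compound 3 `Cc1nn(C)c2nc(NNC(=O)Nc3cc(Cl)nc(Cl)c3)cc(C3CCCCC3)c12` gives the lowest of the three numbers in an assay on isolated protein for binding affinity to sphingosine 1-phosphate receptor 2 (Homo sapiens), read by surface plasmon resonance (on this read-out lower numbers stand for tighter binding and higher numbers for weaker binding), at 2010 nM. Compound 1 `Cc1nn(C)c2nc(NNC(=O)Nc3cc(Cl)nc(Cl)c3)cc(C3CC3)c12` gives 3650 nM, and the step of a 1.8-fold lower number from compound 1 to compound 3 (0.26 log units; within the scatter) stays within the scatter. Compound 2 `Cc1nn(C)c2nc(NNC(=O)Nc3cc(Cl)nc(Cl)c3)cc(-c3ccco3)c12` gives 6520 nM, and the step of a 3.2-fold lower number from compound 2 to compound 3 (0.51 log units; beyond the scatter) is modest but beyond the scatter. Compound 4 `Cc1nn(C)c2nc(NNC(=O)Nc3cc(Cl)nc(Cl)c3)cc(-c3ccccc3)c12` carries a (phenyl in place of cyclohexyl on an aromatic carbon). The step of a 3.2-fold lower number from compound 2 to compound 3 (0.51 log units; beyond the scatter) bears most directly on this change, since it too swaps a six-membered saturated ring against an aromatic one; the step of a 1.8-fold higher number from compound 1 to compound 2 (0.25 log units; within the scatter) also points toward higher numbers for an aromatic group at this position. Compound 4 is therefore expected to give a somewhat higher number in this assay, an estimated step of a 1.9-fold higher number from compound 3 to compound 4 (0.28 log units; within the scatter), with compound 4 estimated at 3800 nM in a range from 1900 nM to 7600 nM.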

Compound 4, dissociation constant: 5320 nM
For compound 4 the middle estimate is 1.4-fold (0.15 log units) below the measured one; measured number inside the range.
By their numbers in this assay, from the lowest: compounds 3, 1, 4 and 2 (each within the scatter of the next, the first and the last beyond it).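

Cyclohexyl and phenyl are both six-membered rings of carbon only, yet in this assay the aromatic ring for the non-aromatic one is a step beyond the scatter (a 2.6-fold higher number from compound 3 to compound 4 (0.42 log units; beyond the scatter)). Phenyl stays within the scatter of furan-2-yl (a 1.2-fold lower number from compound 2 to compound 4 (0.09 log units; within the scatter)) and of cyclopropyl (a 1.5-fold higher number from compound 1 to compound 4 (0.16 log units; within the scatter)), so cyclohexyl now stands apart from both aromatic groups, while cyclopropyl stands apart from neither. Open, as far as these compounds go, is whether a ring carrying an amine, such as piperidine, would shift the number at this position. No available data account for the gap between the two six-membered rings.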